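The source may report more compounds than this note shows. Statements on the series, on what has been measured and on what is new or still open speak of the compounds shown alone.

Compound 1, with the structure `COc1ccc(/C=C/C(=O)c2ccc(OC)c3c2OC(C)(C)C=C3)c(F)c1`, was tested in a functional assay on HepG2 cells (Homo sapiens) for antiproliferative activity, read by MTT assay, with a stated time of 24 h (a lower number here means a stronger inhibitor, a higher number a weaker inhibitor), and gives 7560 nM. It is the only one of the three measured compounds for which a number rather than a limit was obtained. Compound 2, `COc1cc(OC)c(OC)cc1/C=C/C(=O)c1ccc(OC)c2c1OC(C)(C)C=C2`, reaches only the limit of this assay, > 10000 nM. Compound 3, `COc1ccc(C(=O)/C=C/c2ccc(OC)c(OC)c2OC)c2c1C=CC(C)(C)O2`, likewise reaches only the limit, > 10000 nM. Within the data shown here, compound 1 therefore stands alone as the single measured value, the other two sitting at the limit of > 10000 nM in this assay, at which 2 of the 3 values shown sit.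

Compound 4, `COc1ccc(C(=O)/C=C/c2cccc(Cl)c2)c2c1C=CC(C)(C)O2`, has not yet been measured. It differs from compound 1 in one place: 3-chlorophenyl in place of 2-fluoro-4-methoxyphenyl on a double-bonded chain carbon bound to a double-bonded chain carbon. Among the measured compounds shown here, no measured pair differs in a single place, so the size of such a change is not known from these data. Because compound 1 gives 7560 nM, a step of a 1.1-fold lower number from compound 1 to compound 4 (0.03 log units; within the scatter) is expected, that is, nothing beyond the usual scatter. For compound 4 a value of 7000 nM is estimated, within a range from 2000 nM to 20000 nM, and with a real chance that only a limit is returned.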

Compound 4, half-maximal inhibitory concentration: > 10000 nM
Compound 4 was reported as a limit; the forecaster's own chance of this, stated with the estimate: 35%; middle value at least 1.4-fold (0.15 log units) from the limit.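

In this assay compound 4 gives > 10000 nM, which is a limit and not a number. Placing 3-chlorophenyl where 2-fluoro-4-methoxyphenyl stood, on a double-bonded chain carbon bound to a double-bonded chain carbon, gives the only step that can be read here: an at least 1.3-fold higher number from compound 1 to compound 4 (0.12 log units; that floor lies within the scatter). So this swap brings no gain in strength that the read-out can show, although the true size of the step stays unknown and even its floor does not clear the usual scatter, and compound 1 remains the only compound with a number: the limit of > 10000 nM in this assay, at which 3 of the 4 values shown sit.

As far as these compounds go, whether this change matters at all stays open, since only a floor is known for the step. Also open, from the compounds shown here alone, is whether a phenyl ring carrying an amine or a carboxylic acid at this place would give a clearly lower number than compound 1 does.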